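The source may report more compounds than this note shows. Statements on the series, on what has been measured and on what is new or still open speak of the compounds shown alone.

Among the compounds with values here, compound 2 `FC(F)(F)c1ccc(CSc2nc(Nc3ccc(C(F)(F)F)cc3)c3ccccc3n2)cc1` is the only compound of this pair with a number rather than a limit in a functional assay on MDA-MB-231 cells (Homo sapiens) for cytotoxicity, read by MTT assay, with a stated time of 72 h (a lower number here means a stronger inhibitor, a higher number a weaker inhibitor), where compound 2 gives 5460 nM. Compound 1 `CCOc1ccccc1Nc1nc(SCc2ccc(C(F)(F)F)cc2)nc2ccccc12` returns only a limit in this assay, namely > 50000 nM (the limit of > 50000 nM in this assay, at which 1 of the 2 values shown sits). Within the data shown here, the step of an at least 9.1-fold lower number from compound 1 to compound 2 (0.96 log units; beyond the scatter) is therefore the sole measured guide. Compound 3 `COc1ccc(Nc2nc(SCc3ccc(C(F)(F)F)cc3)nc3ccccc23)cc1OC` differs from compound 2 by 3,4-dimethoxyphenyl in place of 4-(trifluoromethyl)phenyl on a nitrogen on an aromatic ring. This change runs the measured step backwards in kind: an alkoxy-bearing phenyl group returns in place of the 4-(trifluoromethyl)phenyl group, as in compound 1, though the 3,4-dimethoxyphenyl group is not the 2-ethoxyphenyl group and the size of the step cannot be read across directly. Compound 3 is thus expected to give a higher number in this assay, by about a 3.7-fold higher number from compound 2 to compound 3 (0.56 log units; beyond the scatter), with a fair chance that only a limit is reported. The estimate for compound 3 in this assay is 20000 nM, within the range 5000 nM to 60000 nM.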

Compound 3, half-maximal inhibitory concentration: 18900 nM
Beside the measured number, compound 3's estimate is 1.1-fold (0.02 log units) above it, within the range that was stated.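

With a measured value on each side, the place on the nitrogen on an aromatic ring now shows a graded response, not just the gap to a limit: a 3.5-fold higher number from compound 2 to compound 3 (0.54 log units; beyond the scatter). An alkoxy-bearing phenyl group there therefore does not by itself remove all measurable activity in this assay, since an at least 2.6-fold lower number from compound 1 to compound 3 (0.42 log units; beyond the scatter). Compound 1 returns only a limit, so the true size of that second step stays unknown: the limit of > 50000 nM in this assay, at which 1 of the 3 values shown sits.

The groups compared differ both in their substituents and in where those substituents sit, so the compounds shown cannot separate these two influences. Going by these compounds, a plain phenyl, a 4-methoxyphenyl or a 2-(trifluoromethyl)phenyl group on this nitrogen would be needed to tell them apart, and how a pyridyl group would behave there remains open.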